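A few compounds are considered here, and "the series" means these few. Any claim that something is new, unique, unknown or untested is made for them only; others in the source may bear on it.

In an ADME assay (liver) for metabolic stability, with Liver microsome (Homo sapiens) as the target, read by LC-MS, using microsomes and NADPH, with a stated time of 5 min, at 37 degrees C (a lower number here means slower removal, a higher number faster removal of the compound), three compounds sharing one core have been measured. Compound 1 `CCn1c([C@@H](C)NS(=O)(=O)c2ccc(Cl)cc2)nc2ccc(C(F)(F)F)cc21` gives > 100 mL.min-1.g-1, which is a limit of the assay and not a number. Compound 3 `CCn1c([C@@H](C)NS(=O)(=O)c2ccc(C)cc2)nc2ccc(C(F)(F)F)cc21` gives > 100 mL.min-1.g-1, also only a limit. That is the limit of > 100 mL.min-1.g-1 in this assay, at which 2 of the 3 values shown sit. Compound 2 `CCn1c([C@@H](C)NS(=O)(=O)c2ccc(F)cc2)nc2ccc(C(F)(F)F)cc21` gives 26 mL.min-1.g-1.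

Fluoro in place of chloro brings an at least 3.8-fold lower number from compound 1 to compound 2 (0.58 log units; beyond the scatter), and methyl in place of fluoro brings an at least 3.8-fold higher number from compound 2 to compound 3 (0.58 log units; beyond the scatter). Compound 4 `CCn1c([C@@H](C)NS(=O)(=O)c2cccc(C#N)c2)nc2ccc(C(F)(F)F)cc21` has 3-cyanophenyl in place of 4-methylphenyl on a sulfonyl sulfur. None of these steps tests a nitrile, so they are a loose guide, but they show that the number can move by a modest step or more when this group changes. A lower number is therefore expected, though with wide uncertainty. The expected change is an at least 3.3-fold lower number from compound 3 to compound 4 (0.52 log units; beyond the scatter). For compound 4 the estimate is 30 mL.min-1.g-1, with an expected range of 10 mL.min-1.g-1 to 100 mL.min-1.g-1.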

Compound 4, intrinsic clearance in microsomes: > 100 mL.min-1.g-1
Compound 4: a limit, no number (the forecaster's own chance of this, stated with the estimate: 20%); middle value at least 3.3-fold (0.52 log units) from the limit.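

Replacing 4-fluorophenyl with 3-cyanophenyl on the sulfonyl sulfur brings an at least 3.8-fold higher number from compound 2 to compound 4 (0.58 log units; beyond the scatter) in this assay, so a nitrile-bearing ring does not keep the lower number of compound 2. The result for compound 4 is a limit and not a number, and its steps from compound 1 and compound 3, also limits, cannot be read. Compound 2 therefore remains the only compound here with a readable number, while the others share one ceiling: the limit of > 100 mL.min-1.g-1 in this assay, at which 3 of the 4 values shown sit.

Going by these compounds, whether an amine or a carboxylic acid on the aromatic ring would give a readable number remains open. On these data alone, how far compound 1, compound 3 and compound 4 differ from one another also remains open.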